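From 3-chlorophenyl to 2-fluorophenyl on a carbonyl carbon

A few compounds are considered here, and "the series" means these few. Any claim that something is new, unique, unknown or untested is made for them only; others in the source may bear on it.

In a functional assay on MDA-MB-231 cells (Homo sapiens) for antiproliferative activity, read by MTT assay, with a stated time of 24 h (on this read-out lower numbers stand for stronger inhibition and higher numbers for weaker inhibition), compound 1 `O=C(NNc1ccccc1Cl)c1cccc(NS(=O)(=O)c2cnc(O)nc2O)c1` gives 2090 nM. Compound 3 `O=C(NNC(=O)c1cccc(NS(=O)(=O)c2cnc(O)nc2O)c1)c1cccc(Cl)c1` gives 3180 nM, and a 1.5-fold higher number from compound 1 to compound 3 (0.18 log units; within the scatter) places it level with compound 1, so the two numeric values cannot be separated. Compound 2 `O=C(NNc1ccccc1F)c1cccc(NS(=O)(=O)c2cnc(O)nc2O)c1` returns only a limit, > 20000 nM. Exchanging chloro for fluoro gives an at least 9.5-fold higher number from compound 1 to compound 2 (0.98 log units; beyond the scatter), while the replacement of 2-fluorophenyl by (3-chlorophenyl)carbonyl gives an at least 6.2-fold lower number from compound 2 to compound 3 (0.79 log units; beyond the scatter).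

Compound 4 `O=C(NNC(=O)c1ccccc1F)c1cccc(NS(=O)(=O)c2cnc(O)nc2O)c1` has not yet been measured. Its difference from compound 3 is 2-fluorophenyl in place of 3-chlorophenyl on a carbonyl carbon, with 2-fluorophenyl in place of 3-chlorophenyl on a carbonyl carbon. Among the compounds with values here, no measured step makes this exact change. The nearest guide is an at least 9.5-fold higher number from compound 1 to compound 2 (0.98 log units; beyond the scatter), which also exchanges chloro for fluoro, although there the ring sits on an amine nitrogen. a 1.5-fold higher number from compound 1 to compound 3 (0.18 log units; within the scatter) shows a chlorinated pair staying within the scatter, so it offers no sign that the carbonyl setting alone moves the number. A rise of modest size is therefore expected, smaller than the fluoro step might suggest, and a limit reading remains possible. The estimate means a 2.8-fold higher number from compound 3 to compound 4 (0.45 log units; beyond the scatter) as the expected step. Compound 4 is estimated at 9000 nM, with an expected range from 2500 nM to 20000 nM.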

Compound 4, half-maximal inhibitory concentration: > 20000 nM
Compound 4: no number, only a limit; the forecaster's own chance of this, stated with the estimate: 35%; middle value at least 2.2-fold (0.34 log units) from the limit.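

On the carbonyl carbon, the exchange of 3-chlorophenyl for 2-fluorophenyl is not neutral in this assay: there is an at least 6.2-fold higher number from compound 3 to compound 4 (0.79 log units; beyond the scatter), so a loss of this kind is no longer confined to a ring on an amine nitrogen. Against the other chlorinated compound there is an at least 9.5-fold higher number from compound 1 to compound 4 (0.98 log units; beyond the scatter), and across these four compounds, with no exception, the two chlorinated members give numbers while the two fluorinated members do not, whichever of the two linkers they carry. The reading for compound 4 is a limit and not a number, the true size of both steps stays unknown, and the step between compound 2 and compound 4 cannot be read: the limit of > 20000 nM in this assay, at which 2 of the 4 values shown sit.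

The change on the carbonyl carbon alters the halogen and its place on the ring together, so the compounds shown cannot say which of the two matters, and 3-fluorophenyl or 2-chlorophenyl on that same carbonyl carbon would separate them. Also open, as far as these compounds go, is how an unsubstituted phenyl or a methoxy group on that ring would read in this assay.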